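This account rests on a few compounds, and the source may have more. Where it says the series, first, only, none or still open, it means among the compounds named here.

For the measured compounds named here, compound 1 `FC(F)(F)c1ccc(CNc2nc(-c3ccccc3C(F)(F)F)nc3ccccc23)cc1` gives 8900 nM in an assay on a protein complex for inhibition of ubiquitin carboxyl-terminal hydrolase 1/WD repeat-containing protein 48 (Homo sapiens), read by fluorescence (on this read-out higher numbers stand for weaker inhibition and lower numbers for stronger inhibition), the highest of the three numbers so far; compound 2 `N#Cc1ccc(CNc2nc(-c3ccccc3C(F)(F)F)nc3ccccc23)cc1` gives 5700 nM and compound 3 `FC(F)(F)c1cc(-c2ccc(CNc3nc(-c4ccccc4C(F)(F)F)nc4ccccc34)cc2)ccn1` gives 4900 nM, both within the scatter of compound 1. The measured steps at the same position, a 1.6-fold lower number from compound 1 to compound 2 (0.19 log units; within the scatter) and a 1.8-fold lower number from compound 1 to compound 3 (0.26 log units; within the scatter), are both within the scatter, as is a 1.2-fold lower number from compound 2 to compound 3 (0.07 log units; within the scatter).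

Compound 4 `FC(F)(F)c1ccccc1-c1nc(NCc2ccc(C3CCCCC3)cc2)c2ccccc2n1` differs from compound 1 as follows: cyclohexyl in place of trifluoromethyl on an aromatic carbon. The comparable changes at this position, the step from compound 1 to compound 2 and that from compound 1 to compound 3, moved the number little, so no step beyond the scatter is expected here either. Compound 4 is therefore estimated at 6500 nM in this assay, range 2500 nM to 17000 nM, meaning an expected step of a 1.4-fold lower number from compound 1 to compound 4 (0.14 log units; within the scatter).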

Compound 4, half-maximal inhibitory concentration: 9800 nM
Estimate against measurement, compound 4: 1.5-fold (0.18 log units) below; the range from low to high includes it.
By their numbers in this assay, from the lowest: compounds 3, 2, 1 and 4 (each within the scatter of the next).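

All four groups at this position, now including cyclohexyl with its non-aromatic ring of carbon only, give numbers within the scatter of one another, with a 1.1-fold higher number from compound 1 to compound 4 (0.04 log units; within the scatter) and a 1.7-fold higher number from compound 2 to compound 4 (0.24 log units; within the scatter) and a 2.0-fold higher number from compound 3 to compound 4 (0.30 log units; within the scatter) all inside it. Across these compounds, neither the ring type nor the size of the group separates the numbers. Nothing available bears on the reason for this result.

From the compounds shown here alone, whether an amine or a carboxylic acid at this position would give a step beyond the scatter remains open, as does the effect of changes elsewhere on the shared core.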